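This account rests on a few compounds, and the source may have more. Where it says the series, first, only, none or still open, it means among the compounds named here.

Three compounds that share one core were tested in an assay on HEK293 cells for displacement of a labelled ligand from B1 bradykinin receptor (Homo sapiens), read by scintillation counting; a higher number here means a weaker inhibitor, a lower number a stronger inhibitor. Compound 1 `CCN(CC)CCN1CCN(C(=O)COCCN(C)S(=O)(=O)c2c(C)cc(OC)cc2C)CC1` gives 10 nM, compound 2 `COc1cc(C)c(S(=O)(=O)N(C)CCOCC(=O)N2CCN([C@@H]3CN4CCC3CC4)CC2)c(C)c1` gives 5.6 nM, and compound 3 `COc1cc(C)c(S(=O)(=O)N(C)CCOCC(=O)N2CCN(CC3CCN(C)CC3)CC2)c(C)c1` gives 4.5 nM, the lowest of the three, though compound 2 sits within the scatter of it. The step of a 2.2-fold lower number from compound 1 to compound 3 (0.35 log units; beyond the scatter) was modest and is the only one here that replaced a chain amine by a ring at this place. Compound 4 `COc1cc(C)c(S(=O)(=O)N(C)CCOCC(=O)N2CCN(CCCN(C)C)CC2)c(C)c1` carries 2-(dimethylamino)ethyl in place of 1-methylpiperidin-4-yl on a saturated chain carbon bound to an amine nitrogen in a ring, so it goes back to a chain, as in compound 1. That earlier step suggests compound 4 will read somewhat higher than compound 3, though a change of this size lies near the scatter. The expected step is a 1.8-fold higher number from compound 3 to compound 4 (0.25 log units; within the scatter). Compound 4 is estimated at 8 nM, between 3.5 nM and 18 nM.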

Compound 4, inhibition constant: 5.8 nM
Compound 4: the middle estimate sits 1.4-fold (0.14 log units) above what was measured; measured number inside the range.
By their numbers in this assay, from the lowest: compounds 3, 2, 4 and 1 (each within the scatter of the next, the first and the last beyond it).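

In this assay the open chain 2-(dimethylamino)ethyl reads level with the 1-methylpiperidin-4-yl ring (a 1.3-fold higher number from compound 3 to compound 4 (0.11 log units; within the scatter)), so at this place a ring is not required for a low number. Compound 4 also stays within the scatter of the two-ring group (a 1.0-fold higher number from compound 2 to compound 4 (0.02 log units; within the scatter)) and of the diethylamino chain (a 1.7-fold lower number from compound 1 to compound 4 (0.24 log units; within the scatter)), so the gap between compound 1 and compound 3 cannot be read as a simple contrast of chain against ring. No measurement here explains these results.

Going by these compounds, how a primary amine or a carboxylic acid in place of the dimethylamino group would read remains open, as does a longer chain.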